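This account rests on a few compounds, and the source may have more. Where it says the series, first, only, none or still open, it means among the compounds named here.

Measured in a functional assay on SK-BR-3 cells (Homo sapiens) for cytotoxicity, read by sulforhodamine B assay, with a stated time of 72 h; on this read-out lower numbers stand for an effect already at smaller amounts and higher numbers for an effect only at larger amounts of compound:
Compound 1 `Cc1cccc(-c2cc3occ(C)c3c(=O)o2)c1`: 1.5 uM
Compound 2 `Cc1ccc(-c2cc3occ(C)c3c(=O)o2)cc1`: > 83.3 uM
Compound 3 `Cc1coc2cc(-c3ccc(O)cc3)oc(=O)c12`: 36 uM

Compound 2 gives no number in this assay, only the limit > 83.3 uM. For the measured compounds named here, it is the one compound of the three that stands there: the limit of > 83.3 uM in this assay, at which 1 of the 3 values shown sits. Compound 4 `Cc1ccc(-c2cc3occ(C)c3c(=O)o2)cc1C` is built on compound 2, and the change is methyl in place of hydrogen on an aromatic carbon, ortho to a methyl group and meta to a large group.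

Going by the values given here, only one measured step starts from compound 2, namely an at least 2.3-fold lower number from compound 2 to compound 3 (0.36 log units; beyond the scatter), which goes beyond the scatter. There, hydroxy takes the place of methyl on an aromatic carbon. Among the compounds with values here, that step is a different change at a different place, so it shows only that compound 2 can be improved on by a change to this ring. Closer to the new methyl is compound 1, whose single methyl on that ring is also meta to a large group, and compound 1 reads 1.5 uM. Compound 4 keeps the methyl of compound 2 as well, so only part of that gain is expected.

An estimated step of an at least 4.1-fold lower number from compound 2 to compound 4 (0.61 log units; beyond the scatter) is therefore expected, toward a lower number. For compound 4 the estimated value is 20 uM, with an expected range of 3 uM to 90 uM.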

Compound 4, concentration for half-maximal effect: 14.6 uM
Compound 4: middle estimate off by 1.4-fold (0.14 log units), on the high side, and the stated range covers the measured number.
By their numbers in this assay, from the lowest: compound 1; then compound 4; then compound 3. At a limit, above all of these: compound 2.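

In this assay, for the compounds shown here, methyl in place of hydrogen on an aromatic carbon, ortho to a methyl group and meta to a large group, gives an at least 5.7-fold lower number from compound 2 to compound 4 (0.75 log units; beyond the scatter), which shows for the first time that a substituent at this position can by itself move the number down. The same kind of change does not act in one direction across these compounds, since methyl in place of hydrogen on an aromatic carbon also gives a 9.7-fold higher number from compound 1 to compound 4 (0.99 log units; beyond the scatter), so its outcome depends on which methyl the ring already carries. The first of these steps has only a lower bound for its size, as compound 2 gives a limit and not a number: the limit of > 83.3 uM in this assay, at which 1 of the 4 values shown sits.

The compounds shown leave open whether this gain belongs to the methyl itself or would also appear with a chlorine, a methoxy or an amine on the same aromatic carbon. They also leave open why the two steps run in opposite directions, and whether a longer chain at this position would lower the number further or raise it.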